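Fluoro to Methoxy: Expected Effect on Cell Toxicity

A few compounds are considered here, and "the series" means these few. Any claim that something is new, unique, unknown or untested is made for them only; others in the source may bear on it.

Measured compounds:
compound 1 `Fc1ccc(-c2ccc3c(NCCCNCc4ccco4)ccnc3c2)cc1` with 7760 nM
compound 2 `CCC(CC)c1ccc2c(NCCCNCc3cccc(OC)c3O)ccnc2c1` with 410 nM
compound 3 `CC(C)(C)c1ccc(Oc2ccc3c(NCCCNCc4ccco4)ccnc3c2)cc1` with 3100 nM

In an ADME assay on HepG2 cells (Homo sapiens) for cytotoxicity, read by luminescence, CellTiter-Glo and ATP content, with a stated time of 72 h (on this read-out lower numbers stand for an effect already at smaller amounts and higher numbers for an effect only at larger amounts of compound), compound 1 gives the highest number of the three. Compound 3 comes nearest and compound 2 lies furthest away, and both gaps are wider than the usual scatter, so compound 1 needs the largest amount of the measured set before an effect appears. The next compound, compound 4 `COc1ccc(-c2ccc3c(NCCCNCc4ccco4)ccnc3c2)cc1`, differs from compound 1 in one place: methoxy in place of fluoro on an aromatic carbon. Among the compounds with values here, no measured pair shows this exact change, so there is no measured step to lean on. The swap is small and leaves the rest of the molecule untouched, so the expected step of a 1.2-fold lower number from compound 1 to compound 4 (0.08 log units; within the scatter) in this assay is small, within the usual scatter. Compound 4 is therefore estimated at 6500 nM, within 2500 nM to 16000 nM.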

Compound 4, half-maximal effective concentration: 6000 nM
Compound 4: middle estimate off by 1.1-fold (0.03 log units), on the high side; the measured number falls inside the stated range.
By their numbers in this assay, from the lowest: compound 2; then compounds 3, 4 and 1 (each within the scatter of the next, the first and the last beyond it).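

Within the data shown here, putting methoxy in place of fluoro, on an aromatic carbon para to a large group, gives the first single-change comparison in this assay: a 1.3-fold lower number from compound 1 to compound 4 (0.11 log units; within the scatter). On this read-out, 4-fluorophenyl and 4-methoxyphenyl therefore cannot be told apart, even though the swap adds a heavy atom and a hydrogen-bond acceptor. Nothing available explains this similarity.

On these data alone, whether an amine or a carboxylic acid at this position would also stay within the scatter remains open. So does whether the same swap would give so small a step on a different core.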